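The source may hold more compounds than are shown below. What is called first, only, known or untested is meant among the compounds shown, and "the series" means these compounds.

Measured compounds:
- compound 1 `Cc1ccccc1C(=O)n1c(-c2cn(-c3ccccc3)nc2-c2ccc(F)cc2)nc2ccccc21`: 189000 nM
- compound 2 `Cc1ccc(-c2nn(-c3ccccc3)cc2-c2nc3ccccc3n2C(=O)c2cncc(C)c2)cc1`: 155000 nM
- compound 3 `O=C(c1ccccc1)n1c(-c2cn(-c3ccccc3)nc2-c2ccc(C(F)(F)F)cc2)nc2ccccc21`: 168000 nM

In an ADME assay on HEK-293T cells (Homo sapiens) for cytotoxicity, read by MTT assay, with a stated time of 24 h (on this read-out lower numbers stand for higher toxicity in this test and higher numbers for lower toxicity in this test), compound 1 gives 189000 nM, the highest of the three numbers, yet compound 3 at 168000 nM and compound 2 at 155000 nM both lie within the scatter of it, so no order can be read among the three. Compound 4 `O=C(c1ccncc1)n1c(-c2cn(-c3ccccc3)nc2-c2ccc(F)cc2)nc2ccccc21` has not been measured in this assay. It differs from compound 1 in one place: pyridin-4-yl in place of 2-methylphenyl on a carbonyl carbon. Going by the values given here, no pair among the measured compounds differs in one place, so no measured step guides this change. Given that the three measured values sit close together, compound 4 is expected to show no step beyond the scatter, a 1.1-fold lower number from compound 1 to compound 4 (0.05 log units; within the scatter). Compound 4 is estimated at 170000 nM, within 90000 nM to 320000 nM.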

Compound 4, half-maximal cytotoxic concentration: 151000 nM
Compound 4: the middle estimate sits 1.1-fold (0.05 log units) above what was measured, within the range that was stated.
By their numbers in this assay, from the lowest: compounds 4, 2, 3 and 1 (each within the scatter of the next).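

In this assay, going by these compounds alone, the one step read at this carbonyl carbon, pyridin-4-yl in place of 2-methylphenyl, is a 1.3-fold lower number from compound 1 to compound 4 (0.10 log units; within the scatter) and so stays within the scatter. At this position, then, a carbon-only aromatic ring gives way to one with a ring nitrogen and a hydrogen-bond acceptor without a step beyond the scatter. No measurement here bears on why that is so. From the compounds shown here alone, whether an amine, a carboxylic acid or a longer chain on this carbonyl carbon would go beyond the scatter remains open. So does whether this step would hold with other groups on the shared core.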